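The source may hold more compounds than are shown below. What is called first, only, known or untested is meant among the compounds shown, and "the series" means these compounds.

Measured compounds in a functional assay on HepG2 cells (Homo sapiens) for antiproliferative activity, read by MTT assay, with a stated time of 48 h; a higher number here means a weaker inhibitor, a lower number a stronger inhibitor:
- compound 1 `CCN1C(=O)C(=O)c2cc(-c3ccc(OC)cc3)ccc21` gives 4470 nM
- compound 2 `C=CCN1C(=O)C(=O)c2cc(-c3ccc(OC)cc3)ccc21` gives 7090 nM

Among the compounds with values here, compound 1 stands at the lowest of the two numbers so far, but its nearest neighbour, compound 2, sits within the scatter: the step of a 1.6-fold higher number from compound 1 to compound 2 (0.20 log units; within the scatter) is the only measured step and shows no change beyond the usual repeat variation.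

Compound 3 `COc1ccc(-c2ccc3c(c2)C(=O)C(=O)N3Cc2ccc3ccccc3c2)cc1` is not yet measured. It differs from compound 1 by naphthalen-2-yl in place of methyl on a saturated chain carbon bound to an amide-type nitrogen in a ring

Within the data shown here, the one measured step bears on this only at the same place of substitution: exchanging methyl for vinyl on that saturated chain carbon gave a 1.6-fold higher number from compound 1 to compound 2 (0.20 log units; within the scatter). The change to naphthalen-2-yl is far larger in what enters, and nothing measured here tells how a group of this size at that place behaves. No step beyond the scatter is therefore expected in this assay on present evidence, with the range held wide to reflect the lack of a comparable step.

Compound 3 is estimated at 3000 nM, between 600 nM and 15000 nM, which as a step means a 1.5-fold lower number from compound 1 to compound 3 (0.17 log units; within the scatter) expected relative to compound 1.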

Compound 3, half-maximal inhibitory concentration: 380 nM
Compound 3: the middle estimate sits 7.9-fold (0.90 log units) above what was measured; measured number below the stated range.
By their numbers in this assay, from the lowest: compound 3; then compounds 1 and 2 (each within the scatter of the next).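

In this assay the saturated chain carbon bound to an amide-type nitrogen in a ring turns out to be a place where one change moves the number far beyond the scatter: naphthalen-2-yl in place of methyl gives a 12-fold lower number from compound 1 to compound 3 (1.07 log units; beyond the scatter) and naphthalen-2-yl in place of vinyl gives a 19-fold lower number from compound 2 to compound 3 (1.27 log units; beyond the scatter) as a second reading of the same effect. The earlier exchange of methyl for vinyl at this place, a 1.6-fold higher number from compound 1 to compound 2 (0.20 log units; within the scatter) as printed, gave no sign of this, so the two small groups say little about what this place accepts, while a group with 2 six-membered aromatic rings of carbon only is clearly accepted here and goes with the lowest number in the series. No measurement on hand accounts for the drop.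

Going by these compounds, it remains open whether the aromatic rings themselves matter or whether any group of similar bulk would do, a question that a phenyl group, a naphthalen-1-yl group or a longer saturated chain at this place would address. Also open, on these data alone, is how a naphthalen-2-yl group carrying an amine or a carboxylic acid would read.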